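The source may hold more compounds than are shown below. What is called first, only, known or untested is meant among the compounds shown, and "the series" means these compounds.

Measured compounds:
compound 1 `CCc1cc(CC)c(OCc2ccccc2)cc1OCCCCCC(C)(C)c1nnn[nH]1` gives 3500 nM
compound 2 `CCCCc1cc(CC)c(O)cc1OCCCCCC(C)(C)c1nnn[nH]1` gives 8700 nM
compound 3 `CCc1cc(C(C)=O)c(OC)cc1OCCCCCC(C)(C)c1nnn[nH]1` gives 5500 nM

All three were tested in an assay on isolated protein for antagonist activity at Bile acid receptor (Homo sapiens), read by HTRF, with a stated time of 30 min; a higher number here means a weaker inhibitor, a lower number a stronger inhibitor. Compound 3 sits second highest of the three numbers, but its nearest neighbour, compound 1, and its furthest, compound 2, both lie within the scatter of repeated measurements, so the three compounds cannot be told apart on these values alone. Among them only compound 1 carries a benzyl group on the aryl oxygen, whereas compound 2 carries a free hydroxyl there and compound 3 a methoxy; compound 1 and compound 2 differ in more than one place, so their values show no single clean step.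

Compound 4 `CCc1cc(C(C)=O)c(OC(C)c2ccccc2)cc1OCCCCCC(C)(C)c1nnn[nH]1` has not yet been measured. It differs from compound 3 in one place: 1-phenylethyl in place of methyl on an oxygen on an aromatic ring. Among the measured compounds shown here, with no single-change step among the measured compounds to lean on, the expectation for a 2.0-fold lower number from compound 3 to compound 4 (0.29 log units; within the scatter) is a modest move toward a lower number, one that may well stay within the scatter. On that basis compound 4 is estimated at 2800 nM, with a likely range from 900 nM to 9000 nM.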

Compound 4, half-maximal inhibitory concentration: 1700 nM
Compound 4: middle estimate off by 1.6-fold (0.22 log units), on the high side, within the range that was stated.
By their numbers in this assay, from the lowest: compound 4; then compounds 1, 3 and 2 (each within the scatter of the next, the first and the last beyond it).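

In this assay, among the compounds shown here, the swap of methyl for 1-phenylethyl on an oxygen on an aromatic ring gives a 3.2-fold lower number from compound 3 to compound 4 (0.51 log units; beyond the scatter) and is the first change in a single place whose size can be read here, a step that lies beyond the scatter. It shows that this oxygen can carry a far larger group, with one heavy atom giving way to eight and a six-membered aromatic ring of carbon added, and that the inhibitor becomes stronger rather than weaker. Nothing measured here explains this gain, so the roles of the added ring, the extra carbons and the branching methyl cannot be separated.

Still open, on these data alone, is how a different group on this oxygen would compare, such as a simple ethyl, a longer chain like hexyl, or a chain ending in an amine or a carboxylic acid. It is also unsettled whether going from methoxy to 1-phenylethoxy would give a step of similar size with other groups elsewhere on the shared core.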